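Swapping the nitrogen substituent in an inhibition series

The compounds below may be only part of what the source reports. "The series", "measured", "known", "first", "only" and "open" are said of these compounds alone.

Measured compounds:
- compound 1 `O=C1COCCN1c1ccc(/N=C\c2c[nH]c3ccccc23)cc1`: 89.1%
- compound 2 `O=C1COCCN1c1ccc(/N=C\c2cn(C(=O)c3ccc(Cl)cc3)c3ccccc23)cc1`: 69.1%

Of the compounds shown here, two have been measured in a functional assay on BV-2 cells (Mus musculus) for inhibition, read by ELISA, tested at 20 uM; on this read-out higher numbers stand for a weaker effect at the one concentration tested and lower numbers for a stronger effect. Compound 1 `O=C1COCCN1c1ccc(/N=C\c2c[nH]c3ccccc23)cc1` carries a hydrogen on the aromatic nitrogen and gives 89.1%. Compound 2 `O=C1COCCN1c1ccc(/N=C\c2cn(C(=O)c3ccc(Cl)cc3)c3ccccc23)cc1` carries a (4-chlorophenyl)carbonyl there instead and gives 69.1%, which is the lowest of the two numbers, so the stronger effect; the step of a number 20 percentage points lower from compound 1 to compound 2 (beyond the scatter) is beyond the scatter.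

Compound 3 `O=C1COCCN1c1ccc(/N=C\c2cn(Cc3ccccc3)c3ccccc23)cc1` is the next one to be measured. The change from compound 2 is benzyl in place of (4-chlorophenyl)carbonyl on an aromatic nitrogen. Among the measured compounds shown here, the only measured step, a number 20 percentage points lower from compound 1 to compound 2 (beyond the scatter), shows that putting a large aromatic group on this nitrogen lowers the number; whether a benzyl does the same as a (4-chlorophenyl)carbonyl is not known from these data, as no step from one to the other has been measured. The expectation is therefore that compound 3 lands close to compound 2, with the step of a number 5.9 percentage points higher from compound 2 to compound 3 (within the scatter) expected to lie within the scatter. Compound 3 is estimated at 75%, in the range 58% to 92%.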

Compound 3, a percentage reported as activity, at one concentration (the size of the read-out at that concentration, not a potency): 182%
For compound 3 the middle estimate is 107 percentage points below the measured one; the whole stated range lies below it.
By their numbers in this assay, from the lowest: compound 2; then compound 1; then compound 3.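

The position is more selective than the first pair suggested: carrying a large group with a six-membered aromatic ring does not by itself lower the number in this assay, since the two groups that share this ring push the read-out in opposite directions from the hydrogen of compound 1. Replacing (4-chlorophenyl)carbonyl with benzyl gives a number 112.9 percentage points higher from compound 2 to compound 3 (beyond the scatter), and replacing the hydrogen with benzyl gives a number 92.9 percentage points higher from compound 1 to compound 3 (beyond the scatter), so benzyl moves the number up, while (4-chlorophenyl)carbonyl moves it down. Nothing available explains why these two groups differ so sharply.

The compounds shown leave open whether the lower number of compound 2 goes with the carbonyl or with the chlorine, a question that phenylcarbonyl and 4-chlorobenzyl on the same nitrogen could separate. They also leave open whether the rise seen with benzyl needs the aromatic ring at all, which a methyl or a longer carbon chain in its place could test.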